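From compound 1 to compound 4 in a growth assay

This account rests on a few compounds, and the source may have more. Where it says the series, first, only, none or still open, it means among the compounds named here.

Compound 1 `Nc1cc(N)c2nc(-c3ccccc3)c(Oc3ccc(Cl)c(Cl)c3)nc2c1` is the reference point of this small set. In a functional assay on SR cells (Homo sapiens) for inhibition, read by sulforhodamine B assay, with a stated time of 48 h (a higher number here means a weaker inhibitor of growth, a lower number a stronger inhibitor of growth), compound 1 gives 24000 nM, the lowest of the two numbers reported so far. Its nearest neighbour is compound 2 `CCOC(=O)[C@H](CCC(=O)O)NC(=O)c1ccc(Sc2nc3cc(N)cc(N)c3nc2-c2ccccc2)cc1`, which in this assay gives 81300 nM, a gap that lies beyond the usual scatter of repeated measurements. Compound 3 `COc1ccc(CNc2nc3cc(N)cc(N)c3nc2-c2ccccc2)cc1` is reported in this assay only as < 100000 nM, which is a limit of the assay rather than a number; this is the limit of < 100000 nM in this assay, at which 1 of the 3 values shown sits.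

The compound still to be tested is compound 4 `Nc1cc(N)c2nc(-c3ccccc3)c(Sc3ccc(F)cc3)nc2c1`. It differs from compound 1 in a single place: (4-fluorophenyl)sulfanyl in place of 3,4-dichlorophenoxy on an aromatic carbon. No comparable change between two measured compounds exists in this set, so neither the direction nor the size of the step can be read from the data at hand. Given that the two groups match closely in what is counted, the expected step is small and should not exceed the scatter: a 1.3-fold higher number from compound 1 to compound 4 (0.10 log units; within the scatter). Compound 4 is therefore estimated to give 30000 nM in this assay, with a plausible range from 8000 nM to 100000 nM.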

Compound 4, concentration for total growth inhibition: < 100000 nM
Compound 4: a limit, no number (the forecaster's own chance of this, stated with the estimate: 20%); the middle value lies beyond the limit too.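

In this assay, among these compounds, compound 4 gives < 100000 nM, which is a limit of the assay and not a number, so no step from compound 1 to compound 4 can be read. The compounds shown leave open whether (4-fluorophenyl)sulfanyl in place of 3,4-dichlorophenoxy on an aromatic carbon shifts growth inhibition, and in which direction. Compound 4 joins compound 3 here: the limit of < 100000 nM in this assay, at which 2 of the 4 values shown sit.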